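From phenyl to furan-3-yl on the chloro compound

The source may hold more compounds than are shown below. What is called first, only, known or untested is meant among the compounds shown, and "the series" means these compounds.

In a functional assay on HL-60 cells (Homo sapiens) for cytotoxicity, read by XTT assay, with a stated time of 3 days (on this read-out higher numbers stand for weaker inhibition and lower numbers for stronger inhibition), compound 1 `OC[C@H]1O[C@@H](n2cc(F)c3c(-c4ccccc4)ncnc32)[C@H](O)[C@@H]1O` gives > 40000 nM as a limit of the assay and not a number. In this assay compound 2 `OC[C@H]1O[C@@H](n2cc(F)c3c(-c4ccco4)ncnc32)[C@H](O)[C@@H]1O` gives 1200 nM and compound 3 `OC[C@H]1O[C@@H](n2cc(Cl)c3c(-c4ccccc4)ncnc32)[C@H](O)[C@@H]1O` gives 1200 nM at the same level. Compound 4 `OC[C@H]1O[C@@H](n2cc(Cl)c3c(-c4ccoc4)ncnc32)[C@H](O)[C@@H]1O` has furan-3-yl in place of phenyl on an aromatic carbon of compound 3, a change counted as furan-3-yl in place of phenyl on an aromatic carbon and still unmeasured.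

Two large steps bear on this, both beyond the scatter and both starting from the limit of > 40000 nM in this assay, at which 1 of the 3 values shown sits, as their upper end. Among the measured compounds shown here, the step of an at least 33-fold lower number from compound 1 to compound 2 (1.52 log units; beyond the scatter) goes with furan-2-yl in place of phenyl and is the nearest precedent. The step of an at least 33-fold lower number from compound 1 to compound 3 (1.52 log units; beyond the scatter) goes with chloro in place of fluoro and shows that compound 3 has already moved far from that limit. For the measured compounds named here, no furan-3-yl compound has been measured, and no furan has been measured with chloro, so only part of the furan-2-yl step is carried over. The expected change is an 8.0-fold lower number from compound 3 to compound 4 (0.90 log units; beyond the scatter) and points towards stronger inhibition. Compound 4 is estimated at 150 nM within an expected range of 30 nM to 800 nM on this read-out.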

Compound 4, half-maximal inhibitory concentration: 2500 nM
Estimate against measurement, compound 4: 17-fold (1.22 log units) below; the measured number lies above the stated range.
By their numbers in this assay, from the lowest: compounds 2 and 3 (each within the scatter of the next); then compound 4. At a limit, above all of these: compound 1.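

In this assay, replacing phenyl with furan-3-yl next to the ring nitrogen of the chloro compound gives a 2.1-fold higher number from compound 3 to compound 4 (0.32 log units; beyond the scatter), so on this compound a five-membered aromatic ring with one oxygen does not bring stronger inhibition at this position. The large change of an at least 33-fold lower number from compound 1 to compound 2 (1.52 log units; beyond the scatter) therefore does not recur in this pair, which differs from it in both the halogen and the furan attachment. Compound 1 remains a limit of the assay and not a number: the limit of > 40000 nM in this assay, at which 1 of the 4 values shown sits.

The compounds shown leave open how furan-2-yl behaves alongside chloro, a comparison that would separate the effect of the halogen from that of the furan attachment. They also leave open how an amine or a methoxy group in place of the aromatic ring at this carbon would read in this assay.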